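The source may hold more compounds than are shown below. What is called first, only, known or untested is meant among the compounds shown, and "the series" means these compounds.

Measured so far in a functional assay on VCaP cells (Homo sapiens) for antiproliferative activity, read by fluorescence and propidium iodide staining, with a stated time of 96 h; a lower number here means a stronger inhibitor, a higher number a weaker inhibitor:

compound 1 `CC(O)(CSc1cccc(OC(F)(F)F)c1)C(=O)Nc1cc(C(F)(F)F)cc(C(F)(F)F)c1`: 9290 nM
compound 2 `CC(O)(CSc1ccccc1OC(F)(F)F)C(=O)Nc1cc(C(F)(F)F)cc(C(F)(F)F)c1`: 2900 nM
compound 3 `CC(O)(CS(=O)(=O)c1cccc(OC(F)(F)F)c1)C(=O)Nc1cc(C(F)(F)F)cc(C(F)(F)F)c1`: 9990 nM

From compound 1 to compound 2 the change is 2-(trifluoromethoxy)phenyl in place of 3-(trifluoromethoxy)phenyl on a sulfur, and in this assay it gave a 3.2-fold lower number from compound 1 to compound 2 (0.51 log units; beyond the scatter). Compound 3 carries the other core; how the core of compound 3 differs from that of compound 1 is not broken down here, and the two values lie within the scatter of each other, so no order between compound 1 and compound 3 is claimed.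

Compound 4 `CC(O)(CS(=O)(=O)c1ccccc1OC(F)(F)F)C(=O)Nc1cc(C(F)(F)F)cc(C(F)(F)F)c1` is not yet measured. It differs from compound 3 by 2-(trifluoromethoxy)phenyl in place of 3-(trifluoromethoxy)phenyl on a sulfonyl sulfur. This is the same kind of change as that from compound 1 to compound 2, not the same: there the place was on a sulfur whose other neighbour is a saturated chain carbon, here it is on a sulfonyl sulfur with the same other neighbour. On these data alone, one occurrence is a thin basis, and the sulfonyl setting is untested, so a smaller step is expected than the earlier one. For compound 4 the expected step is a 2.2-fold lower number from compound 3 to compound 4 (0.35 log units; beyond the scatter) in this assay. The estimate for compound 4 is 4500 nM, between 1800 nM and 12000 nM.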

Compound 4, half-maximal inhibitory concentration: 9950 nM
For compound 4 the middle estimate is 2.2-fold (0.34 log units) below the measured one; measured number inside the range.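

In this assay, 2-(trifluoromethoxy)phenyl in place of 3-(trifluoromethoxy)phenyl on a sulfonyl sulfur gave a 1.0-fold lower number from compound 3 to compound 4 (0.00 log units; within the scatter), so the lower number seen with this change on the core of compound 1 did not carry over to the core of compound 3. The two occurrences of the change disagree: the same change on two cores in this assay, a 3.2-fold lower number (0.51 log units; beyond the scatter) from compound 1 to compound 2 and a 1.0-fold lower number (0.00 log units; within the scatter) from compound 3 to compound 4, 3.2-fold (0.50 log units) apart, beyond the scatter of two such steps. The size of this change therefore cannot be taken from one of these two cores to the other, but with a single pair on each core this gives no rule for any further core and does not show what sets the two steps apart.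

On these data alone, it remains open whether a sulfoxide or an ether oxygen in place of the sulfur or sulfonyl link would behave like the core of compound 1 or the core of compound 3 under this change. Also open, as far as these compounds go, is whether the disagreement between the two steps persists with a chlorine or a nitrile in place of trifluoromethoxy.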